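The compounds below may be only part of what the source reports. "The series", "measured", "known", "first", "only" and "open" are said of these compounds alone.

Series notes, corticotropin-releasing factor receptor 1 binding. Three compounds carry numbers in an assay on isolated protein for binding affinity to corticotropin-releasing factor receptor 1 (Homo sapiens); a lower number here means a stronger inhibitor, a higher number a weaker inhibitor. Compound 1 `CCCN(CCC)c1nc(C)nc(N(CC)c2ccc(N(C)C)cc2C)n1` gives 7 nM in this assay. Compound 2 `CCCCN(CC#N)c1nc(C)nc(N(CC)c2ccc(N(C)C)cc2C(F)(F)F)n1` gives 6 nM in this assay. Compound 3 `CCN(c1nc(C)cc(C)n1)c1c(Br)cc(C(C)C)cc1SC` gives 51 nM in this assay. Compound 2 thus holds the lowest of the three numbers; compound 1 sits within the scatter of it, so no order between those two can be read, while compound 3 lies beyond the scatter with the higher number. Among the compounds with values here, no pair of measured compounds differs in one place, so no single change has a measured step attached to it.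

Compound 4 `CCCN(CCC)c1nc(C)nc(N(CC)c2ccc(N(C)C)cc2C(F)(F)F)n1` is yet to be measured in this assay. Relative to compound 2 the change is dipropylamino in place of butyl(cyanomethyl)amino on an aromatic carbon. Compound 1 already carries dipropylamino on its core and gives 7 nM in this assay, within the scatter of compound 2, so nothing in the measured set separates the two amino groups. The change is therefore expected to give only a small step, no change at the digits printed from compound 2 to compound 4 (within the scatter), with no direction beyond the scatter. For compound 4 the expected value in this assay is 6 nM, with a range from 2 nM to 18 nM.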

Compound 4, inhibition constant: 6 nM
Beside the measured number, compound 4's estimate shows no gap at the digits printed; measured number inside the range.
By their numbers in this assay, from the lowest: compounds 2, 4 and 1 (each within the scatter of the next); then compound 3.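

In this assay, within the data shown here, dipropylamino in place of butyl(cyanomethyl)amino on the aromatic carbon between two ring nitrogen atoms gives no change at the digits printed from compound 2 to compound 4 (within the scatter); this is the first one-place reading at this position, as compounds 1 and 2 differ in more than one place. With dipropylamino held constant, trifluoromethyl in place of methyl on an aromatic carbon gives a 1.2-fold lower number from compound 1 to compound 4 (0.07 log units; within the scatter), so neither change separates its pair in this assay, and the nitrile-bearing chain and the dipropylamino group cannot be told apart here when trifluoromethyl is held constant. Nothing available bears on why either pair stays within the scatter.

As far as these compounds go, both readings come from single pairs, so it remains open whether a primary amine, a dimethylamino group or a longer chain such as dibutylamino at this position would also stay within the scatter, and whether chlorine in place of trifluoromethyl would do the same. Compound 3 differs from compound 4 in more than one place, so its number cannot be tied to either of these positions.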